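This account rests on a few compounds, and the source may have more. Where it says the series, first, only, none or still open, it means among the compounds named here.

In a functional assay on Bel-7402 cells (Homo sapiens) for inhibition, read by sulforhodamine B assay, with a stated time of 72 h (on this read-out higher numbers stand for weaker inhibition and lower numbers for stronger inhibition), compound 1 `C[C@H](Nc1nc(N)nc(N)c1C#N)c1nn(-c2cccc(S(C)(=O)=O)c2)c2cc(F)ccc12` gives 22100 nM and compound 2 `C[C@H](Nc1ncnc2[nH]cnc12)c1nn(-c2cccnc2)c2ccc(F)cc12` gives 31900 nM, two numbers within the usual scatter of each other. For compound 3 `C[C@H](Nc1ncnc2[nH]cnc12)c1nn(-c2cccc(F)c2)c2cc(F)ccc12` the assay reports only a limit, > 40000 nM. Among the measured compounds shown here, compound 1 therefore stands level with the only other compound that has a true number here. Compound 4 `C[C@H](Nc1nc(N)nc(N)c1C#N)c1nn(-c2cccc(S(C)(=O)=O)c2)c2cc(Cl)ccc12` keeps the core of compound 1 but carries chloro in place of fluoro on an aromatic carbon. For the measured compounds named here, no measured pair here differs in one place only, so the data offer no direct guide to this swap. In this assay, no step beyond the scatter is expected, in either direction, and the estimated 1.1-fold lower number from compound 1 to compound 4 (0.04 log units; within the scatter) reflects that. For compound 4 the estimated value is 20000 nM, with an expected range from 10000 nM to 40000 nM.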

Compound 4, half-maximal inhibitory concentration: 4460 nM
Compound 4: the middle estimate sits 4.5-fold (0.65 log units) above what was measured, outside the stated range (below it).
By their numbers in this assay, from the lowest: compound 4; then compounds 1 and 2 (each within the scatter of the next). At a limit, above all of these: compound 3.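

Replacing fluoro with chloro on this aromatic carbon gives a 5.0-fold lower number from compound 1 to compound 4 (0.70 log units; beyond the scatter) in this assay, so this position responds to which halogen it carries, even when one heavy atom simply replaces another. The step comes with no change in the counts of hydrogen-bond donors, acceptors or net charge. Nothing shown here explains why the swap has this effect. From the compounds shown here alone, whether bromo, methyl or methoxy on this carbon would lower the number further stays open, as does whether the same swap would act alike on the core of compound 3.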